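The source may hold more compounds than are shown below. What is called first, only, known or untested is meant among the compounds shown, and "the series" means these compounds.

Compound 1 `Cc1ccccc1-n1nc(-c2ccccc2)nc1CNc1ccc(C(=O)NO)cc1`: 57.1%
Compound 2 `O=C(NO)c1ccc(NCc2nc(-c3ccc(Br)o3)nn2-c2ccccc2)cc1`: 55.8%
Compound 3 `O=C(NO)c1ccc(NCc2nc(-c3cccnc3)nn2-c2ccccc2)cc1`: 57.7%

All three compounds share the same core, a hydroxamic acid attached through an amine to a five-membered ring bearing two aromatic groups. In an assay on Sf9 cells for inhibition of protein deacetylase HDAC6 (Homo sapiens), read by fluorescence, with a stated time of 40 min, tested at 100 nM (on this read-out higher numbers stand for more inhibition at the one concentration tested (going by the name of the read-out) and lower numbers for less inhibition), compound 1 gives 57.1%; this number lies between those of compound 2 and compound 3, but both gaps are within the usual scatter, so the three compounds are not told apart. For the measured compounds named here, the only measured step, a number 1.9 percentage points higher from compound 2 to compound 3 (within the scatter), swaps one aromatic group on an aromatic carbon and also stays within the scatter.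

Compound 4 `Cc1cccc(-n2nc(-c3ccccc3)nc2CNc2ccc(C(=O)NO)cc2)c1` has not yet been measured. It differs from compound 1 by 3-methylphenyl in place of 2-methylphenyl on an aromatic nitrogen. Going by the values given here, no measured step changes the group on this aromatic nitrogen, so nothing directly bears on the change; the one step that is known shows that a swap of an aromatic group elsewhere on the core left this assay unmoved. Because of a number 1.9 percentage points higher from compound 2 to compound 3 (within the scatter), and because compound 1 gives 57.1% close to the other values, no step beyond the scatter is expected in this assay. The estimate for compound 4 is therefore 56%, with a range from 42% to 68%, an expected step of a number 1.1 percentage points lower from compound 1 to compound 4 (within the scatter).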

Compound 4, a percentage reported as inhibition, at one concentration (the size of the read-out at that concentration, not a potency): 66%
Beside the measured number, compound 4's estimate is 10 percentage points below it; low and high end bracket the measured number.
By their numbers in this assay, from the lowest: compounds 2, 1, 3 and 4 (each within the scatter of the next, the first and the last beyond it).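

For the compounds shown here, this is the first measured change to the group on the aromatic nitrogen of the shared core, and in this assay it appears as a number 8.9 percentage points higher from compound 1 to compound 4 (within the scatter), so the two compounds are not told apart. 2-methylphenyl and 3-methylphenyl have the same heavy atoms and the same counts of hydrogen-bond donors and acceptors, so this pair tests only how the same atoms are joined, and that difference does not take the read-out beyond the usual scatter. No measurement is available that would explain the size of this step.

The compounds shown leave open what a different kind of group on this phenyl ring, such as an amine or a carboxylic acid, would do to the read-out. They also leave open whether a longer chain in place of the methyl would give a step beyond the scatter.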